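Two Limits and a Hydroxyl Moved Across the Ring

A few compounds are considered here, and "the series" means these few. Any claim that something is new, unique, unknown or untested is made for them only; others in the source may bear on it.

Compound 1 `Oc1ccc(-c2cc(-c3cccc(F)c3)cc(-c3ccc(O)cc3)n2)cc1` and compound 2 `Oc1ccc(-c2cc(-c3cccc(OC(F)(F)F)c3)cc(-c3ccccc3O)n2)cc1` were both tested in a functional assay on HeLa cells (Homo sapiens) for inhibition; on this read-out lower numbers stand for stronger inhibition and higher numbers for weaker inhibition. In this assay compound 1 gives > 50000 nM, which is a limit of the assay rather than a number. Compound 2 in turn gives > 50000 nM in this assay, again only a limit. Within the data shown here, both results sit at the limit of > 50000 nM in this assay, at which 2 of the 2 values shown sit, so compound 2 stands where compound 1 stands, and no step between the two can be drawn beyond that. Compound 3 `Oc1ccc(-c2cc(-c3cccc(OC(F)(F)F)c3)cc(-c3ccc(O)cc3)n2)cc1` has not yet been measured; it differs from compound 2 by 4-hydroxyphenyl in place of 2-hydroxyphenyl on an aromatic carbon. Among the measured compounds shown here, with no measured step available, and with compound 1 and compound 2 both resting at the limit, the step expected in this assay is a step that the limit leaves unreadable from compound 2 to compound 3, none beyond the scatter. Compound 3 is accordingly estimated at 60000 nM in this assay, with a range from 20000 nM to 200000 nM, most probably reported again as a limit.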

Compound 3, half-maximal inhibitory concentration: > 50000 nM
Compound 3: no number, only a limit; the forecaster's own chance of this, stated with the estimate: 80%; the middle value lies beyond the limit too.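

In this assay compound 3 gives > 50000 nM, a limit and not a number, so the steps to it from compound 1 and compound 2 cannot be read. The compounds shown leave open how they rank against one another, and what change would bring a measurable value: the limit of > 50000 nM in this assay, at which 3 of the 3 values shown sit.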